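From Ethyl to Methoxy: The Step to Compound 4

This account rests on a few compounds, and the source may have more. Where it says the series, first, only, none or still open, it means among the compounds named here.

Compound 1 `COc1cc2c(cc1OC)C(=O)C(C(=O)Nc1ccccc1)C2`: 61.3 ug/mL
Compound 2 `COc1cc2c(cc1OC)C(=O)C(C(=O)Nc1ccc(F)cc1)C2`: 55 ug/mL
Compound 3 `CCc1cccc(NC(=O)C2Cc3cc(OC)c(OC)cc3C2=O)c1`: 64.1 ug/mL
Compound 4 `COc1cccc(NC(=O)C2Cc3cc(OC)c(OC)cc3C2=O)c1`: not yet measured

In a physicochemical assay, with a stated time of 30 min (on this read-out higher numbers stand for weaker inhibition and lower numbers for stronger inhibition), compound 3 gives 64.1 ug/mL, and it stands within the scatter of both other measured compounds. The two steps that reach it show this: a 1.0-fold higher number from compound 1 to compound 3 (0.02 log units; within the scatter), and a 1.2-fold higher number from compound 2 to compound 3 (0.07 log units; within the scatter).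

The next change is methoxy in place of ethyl on an aromatic carbon, meta to a large group (methoxy in place of ethyl on an aromatic carbon). Among the compounds with values here, no measured step makes this exchange, and no measured compound carries methoxy on the ring that holds the ethyl. The closest evidence is the ethyl step above and the step with fluoro in place of hydrogen on an aromatic carbon, a 1.1-fold lower number from compound 1 to compound 2 (0.05 log units; within the scatter). Neither of these leaves the scatter, and the step between the two substituted compounds stays inside it as well. Three compounds are a narrow basis, but they give no reason to expect a real shift, so no step beyond the scatter is expected in this assay, in either direction. The estimated step is a 1.1-fold lower number from compound 3 to compound 4 (0.03 log units; within the scatter). The expected value for compound 4 is 60 ug/mL, with an estimated range from 38 ug/mL to 95 ug/mL.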

Compound 4, half-maximal inhibitory concentration: 38.9 ug/mL
Beside the measured number, compound 4's estimate is 1.5-fold (0.19 log units) above it, within the range that was stated.
By their numbers in this assay, from the lowest: compounds 4, 2, 1 and 3 (each within the scatter of the next).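

In this assay, the place meta to a large group now holds two groups of 2 heavy atoms each, and methoxy in place of ethyl there gives a 1.6-fold lower number from compound 3 to compound 4 (0.22 log units; within the scatter), the largest step among these compounds, yet still inside the scatter. Methoxy in place of hydrogen at that place gives a 1.6-fold lower number from compound 1 to compound 4 (0.20 log units; within the scatter) and 3-methoxyphenyl in place of 4-fluorophenyl on the amide-type nitrogen gives a 1.4-fold lower number from compound 2 to compound 4 (0.15 log units; within the scatter), so compound 4, which carries one hydrogen-bond acceptor more than compound 3 by count, stays within the scatter of compounds 1, 2 and 3. Within the data shown here, no measurement on these compounds gives any account of the size of these steps.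

The compounds shown leave open whether an amine, a carboxylic acid or a longer chain such as propoxy at this same place would give a step beyond the scatter in this assay. They also leave open what methoxy would give on another carbon of that ring, since compound 4 holds it at this one place only.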